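The source may report more compounds than this note shows. Statements on the series, on what has been measured and on what is new or still open speak of the compounds shown alone.

In a functional assay on SMMC-7721 cells (Homo sapiens) for cytotoxicity, read by MTT assay, with a stated time of 24 h (a higher number here means a weaker inhibitor, a lower number a stronger inhibitor), compound 1 `Cc1ccc(S(=O)(=O)N2C/C(=C\c3ccncc3)C(=O)/C(=C/c3ccccc3F)C2)cc1` gives 13200 nM and compound 3 `Cc1ccc(S(=O)(=O)N2C/C(=C\c3ccncc3)C(=O)/C(=C/c3ccccc3C(F)(F)F)C2)cc1` gives 5590 nM. Compound 2 `O=C1/C(=C/c2cccnc2)CN(S(=O)(=O)c2ccc(Br)cc2)C/C1=C\c1ccccc1C(F)(F)F`, at 5760 nM, lies within the scatter of compound 3. Compound 4 `O=C1/C(=C/c2ccncc2)CN(S(=O)(=O)c2ccc(Br)cc2)C/C1=C\c1ccccc1C(F)(F)F` differs from compound 3 by bromo in place of methyl on an aromatic carbon, a change from 4-methylphenyl to 4-bromophenyl. Going by the values given here, no measured step shows this exchange. The only one, a 2.4-fold lower number from compound 1 to compound 3 (0.37 log units; beyond the scatter), is a change of trifluoromethyl for fluoro and bears on it only indirectly. Compound 2 also carries the 4-bromophenyl group, and its 5760 nM gives no sign of a large shift. In this assay, the expected outcome is a 1.0-fold lower number from compound 3 to compound 4 (0.01 log units; within the scatter), so no step beyond the scatter is expected. For compound 4 the estimate is 5500 nM, with an expected range of 2800 nM to 11000 nM.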

Compound 4, half-maximal inhibitory concentration: 10500 nM
The estimate for compound 4 lay 1.9-fold (0.28 log units) below the measured number; measured number inside the range.
By their numbers in this assay, from the lowest: compounds 3, 2, 4 and 1 (each within the scatter of the next, the first and the last beyond it).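

In this assay, the exchange of 4-methylphenyl for 4-bromophenyl can now be read directly, as a 1.9-fold higher number from compound 3 to compound 4 (0.27 log units; within the scatter), so the two groups are not told apart at this place. The exchange of pyridin-3-yl for pyridin-4-yl, with 4-bromophenyl held in place, reads as a 1.8-fold higher number from compound 2 to compound 4 (0.26 log units; within the scatter) and likewise separates neither group. No supporting data bear on these results. The compounds shown leave open whether an amine or a carboxylic acid in place of the bromo would give a step beyond the scatter. They also leave open how 4-methylphenyl behaves alongside pyridin-3-yl.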